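Aryl swap on the hydrazone of a shared core

The compounds below may be only part of what the source reports. "The series", "measured", "known", "first", "only" and "open" are said of these compounds alone.

Two measured compounds share one core and differ only in the aryl group attached to the hydrazone carbon. Compound 1 `Cn1c(=O)c(=O)n(C2CCCC2)c2nc(N/N=C/c3cccc(Cl)c3Cl)ncc21` carries a 2,3-dichlorophenyl group there; in a functional assay on PC-3 cells (Homo sapiens) for antiproliferative activity, read by MTT assay (a higher number here means a weaker inhibitor, a lower number a stronger inhibitor), compound 1 gives 17200 nM. Compound 2 `Cn1c(=O)c(=O)n(C2CCCC2)c2nc(N/N=C/c3cc(C(F)(F)F)cc(C(F)(F)F)c3)ncc21` carries a different aryl group, and in this assay compound 2 gives 8200 nM. Of these two numbers compound 1 stands at the higher one, and the gap between compound 1 and compound 2 lies beyond the usual scatter of the measurement.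

Compound 3 `CSc1ccc(/C=N/Nc2ncc3c(n2)n(C2CCCC2)c(=O)c(=O)n3C)cc1` has not yet been measured. It differs from compound 1 in one place: 4-(methylsulfanyl)phenyl in place of 2,3-dichlorophenyl on a carbon with a double bond to nitrogen. Within the data shown here, no measured pair shows what this particular change does, so the expectation rests only on the two values in hand, both of which sit in a weak range. The step of a 1.4-fold lower number from compound 1 to compound 3 (0.16 log units; within the scatter) is expected to be modest, leaning toward a somewhat lower number but not clearly beyond the scatter. Compound 3 is therefore estimated at 12000 nM, with a range from 4000 nM to 35000 nM.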

Compound 3, half-maximal inhibitory concentration: 21000 nM
Compound 3: the middle estimate sits 1.8-fold (0.24 log units) below what was measured; measured number inside the range.
By their numbers in this assay, from the lowest: compound 2; then compounds 1 and 3 (each within the scatter of the next).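

In this assay, 4-(methylsulfanyl)phenyl in place of 2,3-dichlorophenyl on a carbon with a double bond to nitrogen gives a 1.2-fold higher number from compound 1 to compound 3 (0.09 log units; within the scatter), so this position accepts an exchange of the chlorine-bearing ring for a sulfur-bearing ring of equal heavy-atom count without a readable change in the number. Compound 3 therefore adds a second aryl group at the level of compound 1. Compound 2 gives 8200 nM, and the gap separating compound 1 from compound 2 remains the one gap on this position outside the scatter. The data offer no measurement that would explain why these two aryl groups read alike.

As far as these compounds go, whether any aryl group on this carbon can bring the number far under these values remains open, as all three compounds share the same core and differ only in a substituted phenyl ring. A phenyl ring carrying an amine or a carboxylic acid, or a simple unsubstituted phenyl, would show whether the reading at this position moves with the substituent at all.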